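From pyrrolidin-2-yl to 4-hydroxyphenyl on the shared core

A few compounds are considered here, and "the series" means these few. Any claim that something is new, unique, unknown or untested is made for them only; others in the source may bear on it.

In a functional assay on MDA-MB-231 cells (Homo sapiens) for antiproliferative activity, read by MTT assay, with a stated time of 24 h (on this read-out lower numbers stand for stronger inhibition and higher numbers for weaker inhibition), compound 1 `c1ccc(-c2noc(-c3ccncc3)n2)cc1` is recorded only as a limit, > 1000000 nM. For the measured compounds named here, compound 2 `COc1ccc(-c2noc(C3CCCN3)n2)cc1OC1CCCC1` gives 212000 nM, the only true number available in this assay. Compound 3 `COc1ccc(-c2noc(-c3ccc(O)cc3)n2)cc1OC1CCCC1` keeps the core of compound 2 but carries 4-hydroxyphenyl in place of pyrrolidin-2-yl on an aromatic carbon. Going by the values given here, no measured step exists to size this change, so only a small shift toward stronger inhibition is expected. The estimated step is a 2.1-fold lower number from compound 2 to compound 3 (0.33 log units; beyond the scatter). For compound 3 the expected value is 100000 nM, with an estimated range of 25000 nM to 400000 nM.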

Compound 3, half-maximal inhibitory concentration: 310 nM
Compound 3: middle estimate off by 320-fold (2.51 log units), on the high side, and the stated range ends above it.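

At this place on the shared core, next to the ring nitrogen and next to the ring oxygen, the group alone can move the reading greatly: in this assay, 4-hydroxyphenyl in place of pyrrolidin-2-yl gives a 680-fold lower number from compound 2 to compound 3 (2.83 log units; beyond the scatter). The two groups show the same printed counts of hydrogen-bond donors and acceptors, so those counts do not track this step. As far as these compounds go, what a plain phenyl or a 4-methoxyphenyl would give here stays open, so the step cannot be divided between the aromatic ring and its hydroxyl. Compound 1 is held only as a limit and cannot be sized against the other compounds: the limit of > 1000000 nM in this assay, at which 1 of the 3 values shown sits.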